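Ring-nitrogen substituents on a methylpiperazinyl core: next step

A few compounds are considered here, and "the series" means these few. Any claim that something is new, unique, unknown or untested is made for them only; others in the source may bear on it.

Measured so far in a functional assay on ileum for inhibition of histamine H1 receptor (Cavia porcellus); on this read-out higher numbers stand for weaker inhibition and lower numbers for stronger inhibition:
compound 1 `CN1CCN(c2nc3ccccc3n2CCOCCO)CC1` gives 42 nM
compound 2 `CN1CCN(c2nc3ccccc3n2-c2ccccc2)CC1` gives 760 nM
compound 3 `CCCSCn1c(N2CCN(C)CC2)nc2ccccc21` gives 68 nM

Compound 3 stands second highest of the three numbers in this assay. Its nearest neighbour is compound 1: the step of a 1.6-fold higher number from compound 1 to compound 3 (0.21 log units; within the scatter) is within the scatter, so the two are not to be ordered. Its furthest is compound 2, and here the step of an 11-fold lower number from compound 2 to compound 3 (1.05 log units; beyond the scatter) is large and beyond the scatter.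

Compound 4 `CCCC(C)n1c(N2CCN(C)CC2)nc2ccccc21` is not yet measured. It differs from compound 3 in one place: 1-methylbutyl in place of (propylsulfanyl)methyl on an aromatic nitrogen. Within the data shown here, two measured steps bear on this. The step of a 1.6-fold higher number from compound 1 to compound 3 (0.21 log units; within the scatter) exchanged one open chain for another on the same position and stayed within the scatter; the step of an 11-fold lower number from compound 2 to compound 3 (1.05 log units; beyond the scatter) shows that only the move from an open chain to phenyl on the ring nitrogen has so far produced a large change. The present change keeps an open chain of the same count of heavy atoms, so no step beyond the scatter is expected in this assay, in either direction.

Compound 4 is therefore expected at 70 nM, with a range from 25 nM to 200 nM. For compound 4 this estimate means a step of a 1.0-fold higher number from compound 3 to compound 4 (0.01 log units; within the scatter), expected to lie within the scatter.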

Compound 4, half-maximal inhibitory concentration: 1400 nM
For compound 4 the middle estimate is 20-fold (1.30 log units) below the measured one; the measured number lies above the stated range.
By their numbers in this assay, from the lowest: compounds 1 and 3 (each within the scatter of the next); then compounds 2 and 4 (each within the scatter of the next).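

In this assay the aromatic nitrogen proves sensitive to more than whether its substituent is an open chain: a 21-fold higher number from compound 3 to compound 4 (1.31 log units; beyond the scatter) is large, although both chains hold the same count of heavy atoms and neither has a ring. The step of a 33-fold higher number from compound 1 to compound 4 (1.52 log units; beyond the scatter) is also large, whereas a 1.8-fold higher number from compound 2 to compound 4 (0.27 log units; within the scatter) is within the scatter, so a large step at this position no longer belongs to phenyl alone. By the counts, the change from (propylsulfanyl)methyl to 1-methylbutyl replaces sulfur with carbon and removes the one hydrogen-bond acceptor, but no measurement at hand accounts for the step.

On these data alone, whether the step follows the loss of sulfur or the branched form of 1-methylbutyl stays open, and a straight pentyl chain on this nitrogen would separate the two. As far as these compounds go, how a chain ending in an amine would stand here also remains open.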